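The compounds below may be only part of what the source reports. "The series", "measured", "known", "first", "only" and "open" are said of these compounds alone.

Among the measured compounds shown here, in a functional assay on DU-145 cells (Homo sapiens) for inhibition, read by trypan blue exclusion, with a stated time of 96 h (on this read-out lower numbers stand for stronger inhibition of growth and higher numbers for weaker inhibition of growth), only two compounds have numbers so far. Compound 1 (`COc1ccc(S(=O)(=O)/C(=C/c2ccc(C)s2)C(=O)c2ccc(Cl)cc2)cc1`) gives 25000 nM in this test. Compound 2 (`Cc1ccc(CS/C(=C/c2ccccc2F)C(=O)c2ccc(Cl)cc2)cc1`) gives 10000 nM in the same test, the lower of the two numbers, and the gap between them lies beyond the usual scatter. Both numbers still sit in a weak-looking range, and the two structures differ in more than one place, so this pair shows no effect of any single change.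

Compound 3 (`Cc1ccc(CS/C(=C/c2cc(Cl)cc(Cl)c2)C(=O)c2ccc(Cl)cc2)cc1`) has not yet been measured. It keeps the rest of compound 2 and carries 3,5-dichlorophenyl in place of 2-fluorophenyl on a double-bonded chain carbon bound to a double-bonded chain carbon. For the measured compounds named here, no measured pair here shows what such a swap does, so the expectation in this assay is cautious: a small step toward a lower number, close to the edge of the scatter. The estimated change is a 1.7-fold lower number from compound 2 to compound 3 (0.22 log units; within the scatter) on this reasoning. For compound 3 the expected value is 6000 nM as a best guess, with an estimated range from 2000 nM to 16000 nM around it.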

Compound 3, concentration for 50% growth inhibition: 10000 nM
Compound 3: the middle estimate sits 1.7-fold (0.22 log units) below what was measured; measured number inside the range.
By their numbers in this assay, from the lowest: compounds 2 and 3 (each within the scatter of the next); then compound 1.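

In this assay, putting 3,5-dichlorophenyl in place of 2-fluorophenyl on a double-bonded chain carbon bound to a double-bonded chain carbon gives no change at the digits printed from compound 2 to compound 3 (within the scatter). Among the compounds shown here, this is the first comparison here in which only one place changes, so, unlike the pair of compound 1 and compound 2, it can be tied to a single swap. It shows that this position accepts a ring with two chlorines instead of one fluorine without any change that this test can separate from the scatter, and no measurement here bears on why the number stays put.

Going by these compounds, a single swap between two halogen-bearing phenyl rings says little about the position as a whole, so it remains open whether a phenyl ring carrying an amine or a carboxylic acid, or a longer chain in place of the ring, would shift the number in either direction. On these data alone, it also remains open whether any change at this place can bring the number clearly below that of compound 2, which so far shares its value with compound 3.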